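Dropping Two Fluorines: Expected Clearance of Compound 4

This account rests on a few compounds, and the source may have more. Where it says the series, first, only, none or still open, it means among the compounds named here.

Compound 1 `Cc1nnc(N2CCC(C(=O)N3N=CC[C@H]3c3cc(F)cc(F)c3)CC2)o1` gives 14 mL/min/kg in an ADME assay on the whole organism (Rattus norvegicus) for pharmacokinetics, at a dose of 1 mg/kg by the intravenous route (on this read-out lower numbers stand for slow clearance and higher numbers for fast clearance), the lowest of the three numbers measured here. Compound 2 `O=C(c1cn[nH]c1)N1CCC(C(=O)N2N=CCC2c2ccccc2)CC1` gives 46 mL/min/kg, and compound 3 `N#Cc1cc(N2CCC(C(=O)N3N=CC[C@H]3c3cc(F)cc(F)c3)CC2)ncn1` gives 46 mL/min/kg. For the measured compounds named here, the only recorded single-point step, a 3.3-fold higher number from compound 1 to compound 3 (0.52 log units; beyond the scatter), alters the group on the amine nitrogen, not the aryl ring. Compound 4 `Cc1nnc(N2CCC(C(=O)N3N=CC[C@H]3c3ccccc3)CC2)o1` differs from compound 1 by phenyl in place of 3,5-difluorophenyl on a saturated ring carbon. Going by the values given here, no measured step isolates this change: compound 2 carries a plain phenyl but also differs from compound 1 elsewhere, so its higher number cannot be credited to the phenyl alone. The expected step is therefore small, a 1.3-fold higher number from compound 1 to compound 4 (0.11 log units; within the scatter), within the scatter. Compound 4 is expected to show 18 mL/min/kg, between 9 mL/min/kg and 36 mL/min/kg.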

Compound 4, clearance: 18 mL/min/kg
Compound 4: the middle estimate sits on the measured number at the digits printed, within the range that was stated.
By their numbers in this assay, from the lowest: compounds 1 and 4 (each within the scatter of the next); then compounds 2 and 3 (each within the scatter of the next).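

In this assay, replacing 3,5-difluorophenyl with phenyl on the saturated ring carbon gives a 1.3-fold higher number from compound 1 to compound 4 (0.11 log units; within the scatter). For the compounds shown here, this is the first direct reading at this position, since the earlier step altered only the group on the amine nitrogen, and here the two fluorines can be removed without a difference beyond the scatter. Nothing available explains this result. As far as these compounds go, whether the same holds with the nitrile-bearing six-membered ring on the amine nitrogen stays open. So does the effect of a methoxy group or an amine on the phenyl ring.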